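Thromboxane synthase series: aryl ether change, compound 3 to 4

This account rests on a few compounds, and the source may have more. Where it says the series, first, only, none or still open, it means among the compounds named here.

Measured in an assay for inhibition of Thromboxane-A synthase (Homo sapiens), using microsomes; a lower number here means a stronger inhibitor, a higher number a weaker inhibitor:
compound 1 `O=C(O)CC/C=C\CC1COC(c2ccc([N+](=O)[O-])cc2)OC1c1cccnc1`: 39 nM
compound 2 `O=C(O)CC/C=C\CC1COC(c2ccc3ccccc3c2)OC1c1cccnc1`: 50 nM
compound 3 `Cc1ccc(C#N)c(OC(C)(C)C2OCC(C/C=C\CCC(=O)O)C(c3cccnc3)O2)c1`: 50 nM

Compound 3 stands level with compound 2 at the digits given, the two together being the highest of the three numbers; against compound 1 it shows only a small difference, within the scatter. For the measured compounds named here, the one measured step, a 1.3-fold higher number from compound 1 to compound 2 (0.11 log units; within the scatter), changes an aryl on a saturated ring carbon and lies within the scatter.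

Compound 4 `CC(C)(Oc1ccccc1Br)C1OCC(C/C=C\CCC(=O)O)C(c2cccnc2)O1` differs from compound 3 as follows: 2-bromophenyl in place of 2-cyano-5-methylphenyl on an oxygen on a saturated carbon. Going by the values given here, no measured step touches the group on this oxygen, so the step from compound 1 to compound 2 bears on it only in a general way, showing that exchanging one aryl for another elsewhere on the shared core moved this assay little. The three measured numbers sit close together.

The step of no change at the digits printed from compound 3 to compound 4 (within the scatter) is therefore expected to stay within the scatter, with no clear direction. Compound 4 is estimated at 50 nM, range 20 nM to 130 nM.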

Compound 4, half-maximal inhibitory concentration: 29 nM
For compound 4 the middle estimate is 1.7-fold (0.24 log units) above the measured one, within the range that was stated.
By their numbers in this assay, from the lowest: compounds 4, 1, 2 and 3 (each within the scatter of the next).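

In this assay, exchanging 2-cyano-5-methylphenyl for 2-bromophenyl on the oxygen gives a 1.7-fold lower number from compound 3 to compound 4 (0.24 log units; within the scatter). This is the only step shown at this oxygen, and it indicates that this assay tolerates a change of the aryl group here: the nitrile and methyl leave and a bromine enters, and the step stays within the scatter, even though the leaving group carries a hydrogen-bond acceptor and the entering group carries none. Nothing at hand ties this step to any property of either group.

Going by these compounds, since the nitrile, the methyl and the bromine change in a single step, their separate contributions remain open. Also open, on these data alone, is how the number responds when the aryl group on this oxygen gives way to a non-aromatic group, such as a cyclohexyl, an amine or a longer chain.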